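This account rests on a few compounds, and the source may have more. Where it says the series, first, only, none or still open, it means among the compounds named here.

Working notes on the series. Among the measured compounds shown here, compound 2 `Cc1csc(N/N=C/c2ccc(Cl)cc2Cl)n1` gives 17 nM in an assay on mitochondria for inhibition of Amine oxidase [flavin-containing] B (Bos taurus) (a higher number here means a weaker inhibitor, a lower number a stronger inhibitor), the lowest of the two numbers so far. Compound 1 `Clc1ccc(/C=N/Nc2nc(-c3ccccc3)cs2)cc1` gives 170 nM in this assay, a gap beyond the scatter, though compound 1 and compound 2 differ in two places at once. Compound 3 `Clc1ccc(/C=N/Nc2nc(-c3ccccc3)cs2)c(Cl)c1` has not been measured; it differs from compound 2 by phenyl in place of methyl on an aromatic carbon. For the measured compounds named here, no single-point step of this kind is available, so the expected step from compound 2 to compound 3 is a moderate weakening, a 2.6-fold higher number from compound 2 to compound 3 (0.42 log units; beyond the scatter). Compound 3 is estimated at 45 nM in this assay, between 12 nM and 170 nM.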

Compound 3, inhibition constant: 132 nM
The estimate for compound 3 lay 2.9-fold (0.47 log units) below the measured number, within the range that was stated.
By their numbers in this assay, from the lowest: compound 2; then compounds 3 and 1 (each within the scatter of the next).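

In this assay, phenyl in place of methyl on this aromatic carbon, next to the ring nitrogen, gives a 7.8-fold higher number from compound 2 to compound 3 (0.89 log units; beyond the scatter), so this position responds to the change. Chloro in place of hydrogen on an aromatic carbon gives a 1.3-fold lower number from compound 1 to compound 3 (0.11 log units; within the scatter), which is within the scatter, so among these compounds the larger gap goes with the phenyl-for-methyl change. Nothing at hand explains this step.

As far as these compounds go, whether ethyl, an amine or a carboxylic acid at this position would fall with methyl or with phenyl remains open. Also open, from the compounds shown here alone, is whether the chloro change stays this small when methyl occupies the position.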